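The source may report more compounds than this note shows. Statements on the series, on what has been measured and on what is new or still open speak of the compounds shown alone.

Measured so far:
- compound 1, `CCn1c(CNc2ccccc2)nnc1SCC(=O)Nc1ccccc1`: > 10000 nM
- compound 2, `CCOC(=O)c1ccc(NC(=O)CSc2nnc(CNc3ccccc3)n2CC)cc1`: 1100 nM

In an assay on isolated protein for inhibition of long-chain fatty acid transport protein 1 (Mus musculus) (a lower number here means a stronger inhibitor, a higher number a weaker inhibitor), compound 1 gives > 10000 nM, which is a limit of the assay rather than a number. Compound 2 gives 1100 nM in the same assay. Going by the values given here, the one measured step, an at least 9.0-fold lower number from compound 1 to compound 2 (0.95 log units; beyond the scatter), is therefore known only as a lower bound, because of the limit of > 10000 nM in this assay, at which 1 of the 2 values shown sits. Among the numbers shown, compound 2 holds the only real value; the other entry is a limit, so there is no second number to rank it against.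

Compound 3, `CCn1c(CNc2ccccc2)nnc1SCC(=O)Nc1ccc(C(=O)OC(C)(C)C)cc1`, keeps the whole of compound 2 and changes only the ester: tert-butyl in place of ethyl on an oxygen next to a carbonyl group. Among the compounds with values here, no measured step touches this part of the molecule; the single step known concerns putting the ethoxycarbonyl group onto the ring, not the size of the alkyl on its oxygen. With nothing to point either way, the expectation for compound 3 in this assay is a step of about a 1.1-fold higher number from compound 2 to compound 3 (0.04 log units; within the scatter), within the usual scatter. Compound 3 is thus estimated at 1200 nM, in the range 400 nM to 4000 nM.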

Compound 3, half-maximal inhibitory concentration: > 10000 nM
Compound 3: only a limit was reported (the forecaster's own chance of this, stated with the estimate: 10%); middle value at least 8.3-fold (0.92 log units) from the limit.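

In this assay, going by these compounds alone, the alkyl group on the ester oxygen proves to matter, which the earlier compounds could not show: tert-butyl in place of ethyl gives an at least 9.0-fold higher number from compound 2 to compound 3 (0.95 log units; beyond the scatter). Within the data shown here, the gain from adding an ester to the ring of compound 1 therefore does not hold for every ester, since only the ethoxycarbonyl version, compound 2, has given a real number so far, and this small outer part of the group can decide whether one appears at all. Compound 3 gives > 10000 nM, which is a limit and not a number, and the step from compound 1 to compound 3 cannot be read because both compounds stand at that limit: the limit of > 10000 nM in this assay, at which 2 of the 3 values shown sit.

Open, going by these compounds, is whether a methyl ester or a longer straight chain such as a propyl ester on the same oxygen would hold, improve or lose the activity of compound 2 at 1100 nM. Also open, on these data alone, is whether the ester itself is needed, or whether a carboxylic acid or a primary amide in its place would serve as well.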